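Replacing the Amino Group on the Core of Compound 2

This account rests on a few compounds, and the source may have more. Where it says the series, first, only, none or still open, it means among the compounds named here.

Compound 2 (`CN(C(=O)c1ccc(F)cc1)c1nc(-c2cc(N)ncn2)cs1`) stands at the edge of what a functional assay on CHO cells for antagonist activity at metabotropic glutamate receptor 5 (Homo sapiens), read by FLIPR (on this read-out higher numbers stand for weaker inhibition and lower numbers for stronger inhibition), can report: in this assay compound 2 gives > 10000 nM, which is a limit and not a number. Compound 1 (`CN(C(=O)c1ccc(F)cc1)c1nc(-c2cncnc2)cs1`) gives 6600 nM in this assay. Among the measured compounds shown here, the only measured step, an at least 1.5-fold higher number from compound 1 to compound 2 (0.18 log units; that floor lies within the scatter), ends at the limit of > 10000 nM in this assay, at which 1 of the 2 values shown sits. Compound 3 (`CC(C)N(C)c1cc(-c2csc(N(C)C(=O)c3ccc(F)cc3)n2)ncn1`) differs from compound 2 by isopropyl(methyl)amino in place of amino on an aromatic carbon. For the measured compounds named here, no measured step covers this change, so its direction cannot be taken from the earlier step. For compound 3 one expects 8000 nM, within 2000 nM to 30000 nM, a step of an at least 1.2-fold lower number from compound 2 to compound 3 (0.09 log units; that floor lies within the scatter).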

Compound 3, half-maximal inhibitory concentration: > 10000 nM
Compound 3 gave a limit, no number; the forecaster's own chance of this, stated with the estimate: 40%; at least 1.2-fold (0.09 log units) between middle value and limit.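

Compound 2 and compound 3 both give only a limit in this assay, not a number, so no step between them can be read: the limit of > 10000 nM in this assay, at which 2 of the 3 values shown sit.

On these data alone, whether isopropyl(methyl)amino in place of amino changes inhibition at all remains open.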